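Methylating the bridging nitrogen of a weak melatonin ligand

The source may report more compounds than this note shows. Statements on the series, on what has been measured and on what is new or still open speak of the compounds shown alone.

Compound 1 `CCCC(=O)Nc1ccc(Nc2cccc(OC)c2)cc1`: 31 nM
Compound 2 `COc1cccc(Nc2ccc(NC(=O)C(C)C)cc2)c1`: > 500 nM

In an assay on isolated protein for binding affinity to melatonin receptor type 1A (Homo sapiens) (a higher number here means a weaker inhibitor, a lower number a stronger inhibitor), compound 1 gives 31 nM. Compound 2 stands at the limit of > 500 nM in this assay, at which 1 of the 2 values shown sits, so for it only a limit, not a number, is known. Among the measured compounds shown here, the single measured step, an at least 16-fold higher number from compound 1 to compound 2 (1.20 log units; beyond the scatter), comes from exchanging the chain on the carbonyl carbon and places compound 2 at the weak end of the two values shown.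

Compound 3 `COc1cccc(N(C)c2ccc(NC(=O)C(C)C)cc2)c1` is obtained from compound 2 through (methyl in place of hydrogen on a nitrogen on an aromatic ring). For the measured compounds named here, none of the measured steps involves this nitrogen; the step of an at least 16-fold higher number from compound 1 to compound 2 (1.20 log units; beyond the scatter) concerns a different position and says only how far compound 2 already lies from compound 1. Going by the values given here, with no comparable step on this nitrogen, the direction of the change cannot be read from the data, and the starting point is itself a limit. The expectation is therefore that compound 3 remains a weak binder, with a step that the limit leaves unreadable from compound 2 to compound 3 expected from compound 2 to compound 3 that stays small relative to the uncertainty. Compound 3 is estimated at 1500 nM in this assay, expected to lie between 400 nM and 8000 nM.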

Compound 3, inhibition constant: 106 nM
Compound 3: the middle estimate sits 14-fold (1.15 log units) above what was measured, outside the stated range (below it).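

Among the compounds shown here, the methyl on this nitrogen on an aromatic ring gives the first measured change at this position, and in this assay it moves binding in the stronger direction, with an at least 4.7-fold lower number from compound 2 to compound 3 (0.67 log units; beyond the scatter). The true size of this step may be larger than the printed figure, because compound 2 has only a limit as its starting point: the limit of > 500 nM in this assay, at which 1 of the 3 values shown sits.

The result also shows that, with isopropyl on the carbonyl carbon, the hydrogen on this nitrogen is not needed for a measurable value, as compound 3 has a methyl there instead and still gives a number rather than a limit.

From the compounds shown here alone, whether the same methyl would produce a similar step with the propyl of compound 1 on the carbonyl carbon remains open, and compound 1 and compound 3 differ in two places, so their values cannot isolate the effect of either change. Also open, going by these compounds, is how an ethyl group, a longer chain or an acetyl group on this nitrogen would compare with methyl, and so whether this position favours only the smallest carbon group or tolerates larger ones.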